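Moving the fluorines on the carbamate aryl ring

The compounds below may be only part of what the source reports. "The series", "measured", "known", "first", "only" and "open" are said of these compounds alone.

The shared core of compound 1 `CC(C)=CCC/C(C)=C/COc1cc(=O)n(CCCO)c2c1CC(CC=C(C)C)C(C)(C)C2` carries a 3,7-dimethylocta-2,6-dien-1-yl group on the ring oxygen, and in a functional assay on PANC-1 cells (Homo sapiens) for inhibition, read by MTT assay, with a stated time of 24 h, tested at 10 uM (on this read-out lower numbers stand for less inhibition and higher numbers for more inhibition at the one concentration tested (going by the name of the read-out)), compound 1 gives 18.4%. Compound 2 `CC(C)=CCC1Cc2c(OCCCNC(=O)c3cccs3)cc(=O)n(CCCO)c2CC1(C)C` gives 5.6%, and compound 3 `CC(C)=CCC1Cc2c(OC(=O)Nc3ccc(F)cc3F)cc(=O)n(CCCO)c2CC1(C)C` gives 0%. Compound 3 stands lowest of the three measured numbers: the step of a number 18.4 percentage points lower from compound 1 to compound 3 (beyond the scatter) lies beyond the scatter, whereas the step of a number 5.6 percentage points lower from compound 2 to compound 3 (within the scatter) lies within it, so compound 3 and compound 2 cannot be ordered against each other.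

Compound 4 `CC(C)=CCC1Cc2c(OC(=O)Nc3ccc(F)c(F)c3)cc(=O)n(CCCO)c2CC1(C)C` differs from compound 3 in one place: 3,4-difluorophenyl in place of 2,4-difluorophenyl on an amide-type nitrogen. Going by the values given here, none of the measured steps concerns this change; the steps of a number 12.8 percentage points lower from compound 1 to compound 2 (beyond the scatter) and a number 18.4 percentage points lower from compound 1 to compound 3 (beyond the scatter) both replace the chain on the ring oxygen, not the aryl ring on the carbamate nitrogen. With nothing in the data to suggest a shift, compound 4 is expected to stay close to compound 3, with an estimated step of a number 3 percentage points higher from compound 3 to compound 4 (within the scatter). Compound 4 is therefore estimated at 3%, within a range from 0% to 15%.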

Compound 4, a percentage reported as inhibition, at one concentration (the size of the read-out at that concentration, not a potency): 0%
For compound 4 the middle estimate is 3 percentage points above the measured one; low and high end bracket the measured number.
By their numbers in this assay, from the lowest: compounds 3, 4 and 2 (each within the scatter of the next); then compound 1.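

In this assay, going by these compounds alone, the change from 2,4-difluorophenyl to 3,4-difluorophenyl on the amide-type nitrogen gives no change at the digits printed from compound 3 to compound 4 (within the scatter) and is the first reading at this position, so rearranging the two fluorines leaves the number where it stood. The new aryl ring also keeps the carbamate's standing against both groups on the ring oxygen, with a number 5.6 percentage points lower from compound 2 to compound 4 (within the scatter) and a number 18.4 percentage points lower from compound 1 to compound 4 (beyond the scatter) as the two steps. Nothing available explains this silent change.

On these data alone, compound 3 gives 0% and compound 4 gives 0%, so any effect of fluorine placement in a carbamate with a higher reading remains open. Also open, as far as these compounds go, is how the number would respond to an unsubstituted phenyl ring, a methoxy group on that ring or a longer chain on the amide-type nitrogen.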